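Pyridine-linked hydroxyphenyl isomers and HCT-15 cytotoxicity

This account rests on a few compounds, and the source may have more. Where it says the series, first, only, none or still open, it means among the compounds named here.

Measured compounds:
compound 1, `Oc1ccccc1-c1cc(-c2ccccc2O)nc(-c2ccccc2O)c1`, 2180 nM
compound 2, `Oc1ccc(-c2cc(-c3ccccc3O)cc(-c3ccccc3O)n2)cc1`, 8240 nM
compound 3, `Oc1cccc(-c2cc(-c3ccccc3O)cc(-c3ccccc3O)n2)c1`, 3390 nM

All three were tested in a functional assay on HCT-15 cells (Homo sapiens) for cytotoxicity, read by CCK-8 assay, with a stated time of 4 days; on this read-out higher numbers stand for weaker inhibition and lower numbers for stronger inhibition. Compound 2 gives the highest number of the three: compound 3 lies nearest, a 2.4-fold lower number from compound 2 to compound 3 (0.39 log units; beyond the scatter), and compound 1 lies furthest, a 3.8-fold higher number from compound 1 to compound 2 (0.58 log units; beyond the scatter). Compound 4, `Oc1ccc(-c2cc(-c3ccc(O)cc3)nc(-c3ccccc3O)c2)cc1`, has not yet been measured. It differs from compound 2 in one place: 4-hydroxyphenyl in place of 2-hydroxyphenyl on an aromatic carbon. The same kind of exchange has been seen once already, going from compound 1 to compound 2, where it produced a 3.8-fold higher number from compound 1 to compound 2 (0.58 log units; beyond the scatter); the reverse direction, seen in the pair from compound 2 to compound 3 against compound 1, points the same way. On that basis a second exchange of this kind is expected to raise the number again, though by an uncertain amount. The step from compound 2 to compound 4 in this assay is therefore estimated at a 2.4-fold higher number from compound 2 to compound 4 (0.39 log units; beyond the scatter). Compound 4 is expected to give about 20000 nM in this assay, with a likely range from 8000 nM to 50000 nM.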

Compound 4, half-maximal inhibitory concentration: > 50000 nM
Compound 4: a limit, no number; the forecaster's own chance of this, stated with the estimate: 20%; middle value at least 2.5-fold (0.39 log units) from the limit.
By their numbers in this assay, from the lowest: compounds 1 and 3 (each within the scatter of the next); then compound 2. At a limit, above all of these: compound 4.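

In this assay compound 4 gives > 50000 nM, which is a limit of the assay and not a number. Placing 4-hydroxyphenyl in place of 2-hydroxyphenyl opposite the ring nitrogen, where the earlier compounds showed no change, gives an at least 6.0-fold higher number from compound 2 to compound 4 (0.78 log units; beyond the scatter), so this position also responds to the exchange, in the same direction as the change elsewhere on the core that gave a 3.8-fold higher number from compound 1 to compound 2 (0.58 log units; beyond the scatter). The size of the new step remains only a bound, set by a single compound: the limit of > 50000 nM in this assay, at which 1 of the 4 values shown sits.

The compounds shown leave open how far the number of compound 4 lies beyond that limit. They also leave open what an aminophenyl group or a carboxylic acid would do at the position opposite the ring nitrogen.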